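This account rests on a few compounds, and the source may have more. Where it says the series, first, only, none or still open, it means among the compounds named here.

Compound 1 `CC(=O)Oc1cccc2cc(-c3ccsc3)c(=O)oc12` gives 1820 nM in an assay on CHO cells for displacement of a labelled ligand from transmembrane domain-containing protein TMIGD3 (Homo sapiens); a lower number here means a stronger inhibitor, a higher number a weaker inhibitor. Compound 2 `CC(=O)Oc1ccc2cc(-c3ccsc3)c(=O)oc2c1OC(C)=O` gives 3600 nM.

Among the compounds with values here, of these two numbers, compound 2 holds the larger, yet the only measured step, a 2.0-fold higher number from compound 1 to compound 2 (0.30 log units; within the scatter), does not separate the two. Compound 3 `CC(=O)Oc1ccc2cc(-c3cc(Br)cs3)c(=O)oc2c1OC(C)=O` differs from compound 2 by 4-bromothiophen-2-yl in place of thiophen-3-yl on an aromatic carbon. Within the data shown here, no measured step touches the thiophene part of the shared core; the one step known concerns an acetoxy group elsewhere. With nothing to guide the direction, the expected step is no change at the digits printed from compound 2 to compound 3 (within the scatter), no change beyond the scatter. Compound 3 is therefore estimated at 3600 nM, ranging from 1200 nM to 11000 nM.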

Compound 3, inhibition constant: > 100000 nM
Compound 3 gave a limit, no number (the forecaster's own chance of this, stated with the estimate: 10%); middle value at least 27-fold (1.44 log units) away from the limit.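

The thiophene on the shared core proves to be a place where a single change counts: 4-bromothiophen-2-yl in place of thiophen-3-yl in this assay gives an at least 27-fold higher number from compound 2 to compound 3 (1.44 log units; beyond the scatter). The earlier acetoxy step stayed within the scatter, whereas this one lies beyond it. Compound 3 gave only a limit of the assay, not a number: the limit of > 100000 nM in this assay, at which 1 of the 3 values shown sits.

This single change moves the thiophene's point of attachment and adds bromine together, and the compounds shown do not separate the two. From the compounds shown here alone, whether plain thiophen-2-yl, or an amine or methoxy group on the thiophene, would stay near compound 2 remains open.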